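Series notes: nitro substitution on the imine phenyl

The source may report more compounds than this note shows. Statements on the series, on what has been measured and on what is new or still open speak of the compounds shown alone.

Compound 3 `C(=N/c1sc2c(c1-c1nc3ccccc3s1)CCCC2)\c1ccccc1` holds the lowest of the three numbers in an ADME assay on cells (Rhabdomyosarcoma cell, Homo sapiens) for cytotoxicity, read by MTT assay, with a stated time of 72 h (a lower number here means that less compound is tolerated, a higher number that more compound is tolerated), giving 71.1 ug/mL. The parent amine, compound 1 `Nc1sc2c(c1-c1nc3ccccc3s1)CCCC2`, gives 253 ug/mL, and a 3.6-fold lower number from compound 1 to compound 3 (0.55 log units; beyond the scatter). Compound 2 `Clc1ccccc1/C=N/c1sc2c(c1-c1nc3ccccc3s1)CCC2` gives 123 ug/mL, which lies within the scatter of compound 3. Compound 4 `O=[N+]([O-])c1ccccc1/C=N/c1sc2c(c1-c1nc3ccccc3s1)CCCC2` differs from compound 3 by nitro in place of hydrogen on an aromatic carbon. Going by the values given here, no measured step covers this exact change; the step from compound 1 to compound 3 concerns the whole added group, not a substituent on it. Among the compounds with values here, the only guidance is the comparison of compound 2 with compound 3, whose values lie within the scatter although compound 2 also differs in its saturated ring. Accordingly, a 1.1-fold higher number from compound 3 to compound 4 (0.05 log units; within the scatter) is expected to stay within the scatter. Compound 4 is estimated at 80 ug/mL, with a range from 35 ug/mL to 180 ug/mL.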

Compound 4, half-maximal cytotoxic concentration: 255 ug/mL
Compound 4: middle estimate off by 3.2-fold (0.50 log units), on the low side, outside the stated range (above it).
By their numbers in this assay, from the lowest: compounds 3 and 2 (each within the scatter of the next); then compounds 1 and 4 (each within the scatter of the next).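

In this assay, nitro in place of hydrogen on an aromatic carbon gives a 3.6-fold higher number from compound 3 to compound 4 (0.55 log units; beyond the scatter) and so shows that a substituent on the added phenyl can move the number beyond the scatter, which the step for the whole added group could not show. Compound 4 lies within the scatter of the parent amine, compound 1, so the lower number of compound 3 does not extend to this imine. No evidence on the origin of this step is available.

Open, from the compounds shown here alone, is whether an amine or a methoxy group at the same place moves the number as nitro does. Also open, going by these compounds, is whether nitro elsewhere on the phenyl ring gives a similar step.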